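Cytotoxicity on liver cells: a ring returns in place of an amine

A few compounds are considered here, and "the series" means these few. Any claim that something is new, unique, unknown or untested is made for them only; others in the source may bear on it.

Measured so far:
Compound 1 `OC[C@H]1O[C@@H](n2cnc3c(CSc4ccccn4)ncnc32)[C@H](O)[C@@H]1O` in a functional assay on Huh-7 cells (Homo sapiens) for cytotoxicity, read by MTT assay, with a stated time of 3 days (on this read-out higher numbers stand for lower toxicity in this test and lower numbers for higher toxicity in this test), compound 1 gives > 100000 nM, a limit of this assay rather than a number.
Compound 2 `O=c1ccn(Cc2ncnc3c2ncn3[C@@H]2O[C@H](CO)[C@@H](O)[C@H]2O)cc1` in this assay compound 2 gives > 100000 nM, likewise a limit.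
Compound 3 `CC(C)N(Cc1ncnc2c1ncn2[C@@H]1O[C@H](CO)[C@@H](O)[C@H]1O)C(C)C` in this assay compound 3 gives 18000 nM.

Going by the values given here, compound 3 thus stands as the only measured number in this assay; the other two values sit at the limit of > 100000 nM in this assay, at which 2 of the 3 values shown sit. The next compound, compound 4 `O=c1ccccn1Cc1ncnc2c1ncn2[C@@H]1O[C@H](CO)[C@@H](O)[C@H]1O`, carries the change (a group of 7 heavy atoms (5 carbon, 1 nitrogen, 1 oxygen; one six-membered aromatic ring with 1 hetero atom) in place of a group of 7 heavy atoms (6 carbon, 1 nitrogen; no ring), on a saturated chain carbon bound to an aromatic carbon).

Among the compounds with values here, two measured steps bear on this. The step of an at least 5.5-fold lower number from compound 2 to compound 3 (0.74 log units; beyond the scatter) runs in the opposite sense to the change now considered, and the step of an at least 5.5-fold lower number from compound 1 to compound 3 (0.74 log units; beyond the scatter) points the same way, both at least modest. Reversing that kind of change from compound 3 to compound 4 therefore leads one to expect a higher number in this assay, most likely back up to the limit shared by compounds 1 and 2.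

Compound 4 is expected to give 100000 nM, with a range from 35000 nM to 300000 nM. The expected step is a 5.6-fold higher number from compound 3 to compound 4 (0.74 log units; beyond the scatter).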

Compound 4, half-maximal cytotoxic concentration: > 100000 nM
Compound 4 was reported as a limit; the forecaster's own chance of this, stated with the estimate: 70%; the middle value lies on the limit itself.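

Placing the six-membered aromatic ring with 1 hetero atom on the saturated chain carbon bound to an aromatic carbon, in place of diisopropylamino, gives an at least 5.5-fold higher number from compound 3 to compound 4 (0.74 log units; beyond the scatter) in this assay. Going by these compounds alone, compound 1, compound 2 and compound 4 each carry such a ring at this place and all sit at the limit, while compound 3, with no ring there, is the only one with a number: the limit of > 100000 nM in this assay, at which 3 of the 4 values shown sit. The steps from compound 1 and from compound 2 to compound 4 cannot be read, and these three compounds stay unordered.

The compounds shown leave open whether a smaller amine such as dimethylamino, or piperidin-1-yl, on this carbon would also give a number in this assay. They also leave open how far beyond the limit the ring-bearing compounds lie.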